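Replacing the 1-acetamidoethyl group of compound 2

The compounds below may be only part of what the source reports. "The series", "measured", "known", "first", "only" and "open" are said of these compounds alone.

- compound 1 `CC(=O)Nc1nc(-c2ccc(Cl)cc2)cs1` gives 1000 nM
- compound 2 `CC(=O)N[C@@H](C)C(=O)NC1=NN(c2ccc(Cl)c(Cl)c2)CC1` gives 58000 nM

These two numbers come from a physicochemical assay for solubility, measured as kinetic solubility, with a stated time of 1 h, at pH 7.4 (a lower number here means a less soluble compound, a higher number a more soluble compound), and they lie apart by more than the usual scatter. Compound 2 stands higher of the two, with 58000 nM as its reading.

Compound 3 `O=C(NC1=NN(c2ccc(Cl)c(Cl)c2)CC1)c1cccnn1` has not been measured yet. It differs from compound 2 in one place, with pyridazin-3-yl in place of 1-acetamidoethyl on a carbonyl carbon as the change. Going by the values given here, no measured pair in this small set shows what such a swap does, so any expectation here is a judgement and not a trend. Among the compounds with values here, compound 2 sits at the top of only two values, and a fall from its 58000 nM reading seems likelier than a further rise. A drop beyond the scatter is expected, and the estimated size is a 3.9-fold lower number from compound 2 to compound 3 (0.59 log units; beyond the scatter) in this assay for this swap. Compound 3 is expected near 15000 nM with a range from 3000 nM to 60000 nM as the estimate.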

Compound 3, solubility: 67000 nM
The estimate for compound 3 lay 4.5-fold (0.65 log units) below the measured number; the measured number lies above the stated range.
By their numbers in this assay, from the lowest: compound 1; then compounds 2 and 3 (each within the scatter of the next).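

On the carbonyl carbon whose other neighbour is the amide-type nitrogen, putting pyridazin-3-yl in place of 1-acetamidoethyl gives, in this assay, a 1.2-fold higher number from compound 2 to compound 3 (0.06 log units; within the scatter), so the two readings cannot be told apart. This pair shows that an open chain with a defined stereocentre and 1 hydrogen-bond donor can give way to a six-membered aromatic ring with 2 hetero atoms and 0 hydrogen-bond donors, and the reading stays at the same level, something the earlier two compounds, which differ in more than one place, could not show. No other measurement accompanies this pair, so the data give no explanation for the match between the two readings.

Still open, on these data alone, is how far this tolerance extends, since one pair says nothing about a simple amine, a carboxylic acid or a longer chain on the same carbonyl carbon. Also open, as far as these compounds go, is whether pyridazin-3-yl would give a similar result on the core of compound 1, which cannot be compared directly with either of the other two compounds.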